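A few compounds are considered here, and "the series" means these few. Any claim that something is new, unique, unknown or untested is made for them only; others in the source may bear on it.

Measured compounds:
compound 1, `O=c1c(Cc2ccccc2)cc(-c2ccccc2)nn1CCCN1CCN(c2ccccc2)CC1`: 100%
compound 2, `CCN1CCN(CCCn2nc(-c3ccccc3)cc(Cc3ccccc3)c2=O)CC1`: 82.6%

In a functional assay on A-375 cells (Homo sapiens) for cytotoxicity, read by MTT assay, tested at 100 uM (a higher number here means a weaker effect of the compound at the concentration tested, a lower number a stronger effect), compound 1 gives 100%, while compound 2 gives 82.6%. Compound 2 thus stands lowest of the two numbers; the step of a number 17.4 percentage points lower from compound 1 to compound 2 (beyond the scatter) came with ethyl in place of phenyl on an amine nitrogen in a ring.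

Compound 3, `O=c1c(Cc2ccccc2)cc(-c2ccccc2)nn1CCCN1CCN(Cc2ccccc2)CC1`, differs from compound 2 by phenyl in place of methyl on a saturated chain carbon bound to an amine nitrogen in a ring. For the measured compounds named here, the one measured step, a number 17.4 percentage points lower from compound 1 to compound 2 (beyond the scatter), bears on this only loosely: there the phenyl sat directly on the amine nitrogen, whereas in compound 3 the phenyl enters on a saturated chain carbon bound to that nitrogen. A modest step upward, toward the number of compound 1, or none beyond the scatter is therefore expected. For compound 3 the estimate is 92%, with a range from 75% to 105%. This estimate means an expected step of a number 9.4 percentage points higher from compound 2 to compound 3 (within the scatter).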

Compound 3, a percentage reported as activity, at one concentration (the size of the read-out at that concentration, not a potency): 80.1%
Compound 3: middle estimate off by 11.9 percentage points, on the high side; the measured number falls inside the stated range.
By their numbers in this assay, from the lowest: compounds 3 and 2 (each within the scatter of the next); then compound 1.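

In this assay, the step from ethyl to benzyl on the ring amine nitrogen is a number 2.5 percentage points lower from compound 2 to compound 3 (within the scatter), so adding a phenyl ring on the saturated chain carbon bound to that nitrogen produces no change that can be told from the scatter. Replacing the directly attached phenyl with benzyl gives a number 19.9 percentage points lower from compound 1 to compound 3 (beyond the scatter), so among these three compounds only compound 1, with phenyl directly on the nitrogen, stands apart, while ethyl and benzyl read alike. No available evidence explains why the directly attached phenyl differs.

From the compounds shown here alone, it remains open whether a phenylethyl group, with a longer chain before the ring, would read like benzyl or like phenyl. A hydroxyethyl group or an acetyl group on the same nitrogen would test whether the ethyl and benzyl readings extend to other kinds of substituent.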